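This account rests on a few compounds, and the source may have more. Where it says the series, first, only, none or still open, it means among the compounds named here.

Measured in a functional assay on A-375 cells (Homo sapiens) for cytotoxicity, read by MTT assay, with a stated time of 72 h, tested at 1 uM; a higher number here means more inhibition of growth at the concentration tested, a lower number less inhibition of growth:
Compound 1, `N/C(=N\NC(=S)N1CCCCCC1)c1ccccn1`: 67%
Compound 2, `Cc1ccnc(/C(N)=N/NC(=S)N2CCOCC2)c1`: 43.2%

Among the measured compounds shown here, of the two compounds measured so far, compound 1 gives the higher number in this assay; compound 2 sits lower by a margin that exceeds the usual scatter. The two differ from each other in more than one place, so their values alone say nothing about any single change.

Compound 3, `Cc1ccnc(/C(N)=N/NC(=S)N2CCCCCC2)c1`, is not yet measured. It differs from compound 1 in one place: methyl in place of hydrogen on an aromatic carbon. For the measured compounds named here, no measured pair isolates this change, so there is no direct guide to its size. With only compound 1 as an anchor, the expected step from compound 1 to compound 3 is a number 9 percentage points lower from compound 1 to compound 3 (within the scatter), a small move that could well stay within the scatter. Compound 3 is therefore estimated at 58%, with a plausible range from 35% to 78%.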

Compound 3, percent growth inhibition at one concentration: 61.9%
The estimate for compound 3 lay 3.9 percentage points below the measured number; the measured number falls inside the stated range.
By their numbers in this assay, from the lowest: compound 2; then compounds 3 and 1 (each within the scatter of the next).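

In this assay, among the compounds shown here, methyl in place of hydrogen on an aromatic carbon, opposite the ring nitrogen, gives a number 5.1 percentage points lower from compound 1 to compound 3 (within the scatter) and is the first change here that can be read on its own. This pair therefore shows that, with the rest of compound 1 kept the same, a methyl at this position leaves growth inhibition at a level that cannot be told apart from that with hydrogen. Nothing at hand explains this result.

As far as these compounds go, a single small group at one position cannot show how much room for change this place allows, so the effect of a chlorine atom, a methoxy group, an amine or a longer chain such as propyl there remains open. From the compounds shown here alone, whether methyl at another carbon of this ring gives a similar result also remains open.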